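The compounds below may be only part of what the source reports. "The series", "measured", "known", "first", "only" and "open" are said of these compounds alone.

Compound 1 `CC(C)/C=C/C(=O)Nc1cc2c(N3CCc4ccccc43)ncnc2cc1O[C@@H]1CCOC1` gives 11200 nM in a functional assay on PC-3 cells (Homo sapiens) for antiproliferative activity, read by MTT assay, with a stated time of 72 h; on this read-out higher numbers stand for weaker inhibition and lower numbers for stronger inhibition. Compound 2 `CCC/C=C/C(=O)Nc1cc2c(N3CCc4ccccc43)ncnc2cc1O[C@@H]1CCOC1` gives 9230 nM in this assay. Compound 3 `COc1cc2ncnc(N3CCCc4ccccc43)c2cc1NC(=O)/C=C/C(C)C` gives 8430 nM in this assay.

Compound 2 differs from compound 1 in one place only: propyl in place of isopropyl on a double-bonded chain carbon bound to a double-bonded chain carbon. This change gave a 1.2-fold lower number from compound 1 to compound 2 (0.08 log units; within the scatter), so the two numbers cannot be told apart with confidence. Compound 3 rests on a different core than compound 1; the difference between the two cores is not broken down here, and the two values sit within the scatter of each other.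

Compound 4 `CCC/C=C/C(=O)Nc1cc2c(N3CCCc4ccccc43)ncnc2cc1OC` has not yet been measured. It stands to compound 3 exactly as compound 2 stands to compound 1: propyl in place of isopropyl on a double-bonded chain carbon bound to a double-bonded chain carbon, the same change at the same place. The step from compound 3 to compound 4 is therefore expected to be small, a 1.2-fold lower number from compound 3 to compound 4 (0.07 log units; within the scatter), since a 1.2-fold lower number from compound 1 to compound 2 (0.08 log units; within the scatter) stayed within the scatter. On that basis compound 4 is expected to give about 7200 nM in this assay, with a likely range from 3600 nM to 14400 nM.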

Compound 4, half-maximal inhibitory concentration: 2240 nM
Compound 4: the middle estimate sits 3.2-fold (0.51 log units) above what was measured, outside the stated range (below it).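

On the core of compound 3, putting propyl in place of isopropyl gave a 3.8-fold lower number from compound 3 to compound 4 (0.58 log units; beyond the scatter) in this assay, so on this core the two chains are clearly separated by the assay. For the compounds shown here, the same swap on the core of compound 1 produced no step that could be told from scatter, which means the effect of this change did not carry over unchanged from one core to the other: the same change on two cores in this assay, a 1.2-fold lower number (0.08 log units; within the scatter) from compound 1 to compound 2 and a 3.8-fold lower number (0.58 log units; beyond the scatter) from compound 3 to compound 4, 3.1-fold (0.49 log units) apart, beyond the scatter of two such steps What this does not show is which of the differences between the two cores is responsible, and with only one pair on each core it sets no general rule for other cores.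

The compounds shown leave open whether a longer chain than propyl, or an amine at the end of the chain, would lower the number further on either core. As far as these compounds go, it also remains open how the swap would behave on a core that combines parts of the core of compound 1 with parts of the core of compound 3.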